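Freeing the Phenol: From Compound 1 to Compound 4

A few compounds are considered here, and "the series" means these few. Any claim that something is new, unique, unknown or untested is made for them only; others in the source may bear on it.

Compound 1 `CC(=O)Oc1cccc2cc(-c3cccs3)c(=O)oc12` was tested in a functional assay on isolated protein for antagonist activity at adenosine receptor A2b (Homo sapiens); on this read-out higher numbers stand for weaker inhibition and lower numbers for stronger inhibition. In this assay compound 1 gives only a limit, > 30000 nM, so its true position is not pinned down. Two close relatives share that fate. Compound 2 `CC(=O)Oc1cccc2cc(-c3ccsc3)c(=O)oc12` carries thiophen-3-yl in place of thiophen-2-yl, and in this assay compound 2 likewise reaches only the limit > 30000 nM. Compound 3 `CC(=O)Oc1cccc2cc(-c3cc(Br)cs3)c(=O)oc12`, with bromo in place of hydrogen on an aromatic carbon, in this assay gives the limit > 30000 nM. The steps among them are therefore unreadable: a step that the two limits leave unreadable from compound 1 to compound 2, a step that the two limits leave unreadable from compound 1 to compound 3 and a step that the two limits leave unreadable from compound 2 to compound 3 all rest on (the limit of > 30000 nM in this assay, at which 3 of the 3 values shown sit).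

The step to compound 4 `O=c1oc2c(O)cccc2cc1-c1cccs1` is of a different kind: hydrogen in place of acetyl on an oxygen on an aromatic ring, which cut one bond further out reads acetoxy to hydroxy. Among the compounds with values here, none of the measured steps touch this oxygen, and none has a readable size, so they set no expectation for direction or size here. Within the data shown here, the only anchor is that compound 1 sits at the limit. Compound 4 is therefore expected to give about 15000 nM, within 2000 nM to 60000 nM, with a fair chance of another limit. That expected step, an at least 2.0-fold lower number from compound 1 to compound 4 (0.30 log units; that floor lies within the scatter), is a cautious guess, no more.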

Compound 4, inhibition constant: > 30000 nM
Compound 4 ended at the assay's limit (the forecaster's own chance of this, stated with the estimate: 55%); middle value at least 2.0-fold (0.30 log units) from the limit.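

In this assay compound 4 gives > 30000 nM as a limit only. Within the data shown here, compound 1 also stands at a limit, so no step between compound 1 and compound 4 can be read: the limit of > 30000 nM in this assay, at which 4 of the 4 values shown sit.

As far as these compounds go, whether acetoxy and hydroxy differ in true inhibition remains open, as do the true values of all four compounds.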